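Series notes: chalcone-type compounds on a shared core

The compounds below may be only part of what the source reports. "The series", "measured", "known", "first", "only" and "open" are said of these compounds alone.

Measured so far:
Compound 1, `COc1ccc(-c2cc(C(=O)/C=C/c3ccccc3)nc3cc(-c4ccccc4)nn23)cc1OC`, gives 15600 nM in a functional assay on DU-145 cells (Homo sapiens) for antiproliferative activity, read by MTT assay, with a stated time of 24 h; on this read-out higher numbers stand for weaker inhibition and lower numbers for stronger inhibition.
Compound 2, `COc1ccc(-c2cc(/C=C/C(=O)c3ccccc3)nc3cc(-c4ccccc4)nn23)cc1`, gives 13700 nM in this assay.

The two numbers for compound 1 and compound 2 differ by an amount inside the usual scatter, so neither stands apart from the other, and no ordering between them is claimed. Both compounds sit at the weak end of what this assay resolves.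

Compound 3, `COc1ccc(-c2cc(/C=C/C(=O)c3ccccc3)nc3cc(-c4ccccc4)nn23)cc1OC`, is the next compound to be measured in this assay. Relative to compound 2 it differs in one place: methoxy in place of hydrogen on an aromatic carbon. Among the measured compounds shown here, no comparable step between measured compounds is available here, so the size of this step is not grounded in a measured pair. Given that compound 1 and compound 2, which already differ in more than this one place, give numbers that are indistinguishable in this assay, the expectation is that the step from compound 2 to compound 3 is small, with no direction beyond the scatter. For compound 3 the estimate is 12000 nM, with a range from 4500 nM to 32000 nM. The step that this estimate implies is expected to be a 1.1-fold lower number from compound 2 to compound 3 (0.06 log units; within the scatter).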

Compound 3, half-maximal inhibitory concentration: 10000 nM
Compound 3: middle estimate off by 1.2-fold (0.08 log units), on the high side, within the range that was stated.
By their numbers in this assay, from the lowest: compounds 3, 2 and 1 (each within the scatter of the next).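

Adding a second methoxy to the aromatic ring, taking 4-methoxyphenyl to 3,4-dimethoxyphenyl, gives in this assay a measured step at this position, ortho to a methoxy group and meta to a large group: a 1.4-fold lower number from compound 2 to compound 3 (0.14 log units; within the scatter). So this position carries the extra methoxy without any separation of the two numbers, and this is the first measured pair for that replacement. With the 3,4-dimethoxyphenyl group held, the pair with 2-benzoylethenyl in place of (2-phenylethenyl)carbonyl gives a 1.6-fold lower number from compound 1 to compound 3 (0.19 log units; within the scatter), so the two orientations of the linker are not told apart here either, and no information bears on why these numbers sit so close.

Still open, from the compounds shown here alone, is whether a different group on this aromatic carbon, such as a hydroxyl, an amine or a longer alkoxy chain, would give a number that stands clear of the scatter. Also open, going by these compounds, is whether a substituent such as a chlorine or a carboxylic acid on the unsubstituted phenyl of the benzoyl group would move the number in this assay beyond what these three compounds show.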